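Cytotoxicity of a Chromone Amide Pair and an Ethoxy Analogue

The source may report more compounds than this note shows. Statements on the series, on what has been measured and on what is new or still open speak of the compounds shown alone.

Compound 1 `COc1ccc2c(=O)c(/C=C/C(=O)Nc3ccccc3Cl)coc2c1` and compound 2 `COc1ccc(NC(=O)/C=C/c2coc3cc(O)ccc3c2=O)cc1` were both examined in an ADME assay on HepG2 2.2.15 cells (Homo sapiens) for cytotoxicity, read by MTT assay, with stated times of 48 h and 9 days; a lower number here means that less compound is tolerated, a higher number that more compound is tolerated. In this assay compound 1 gives 1010000 nM, and compound 2 gives 976000 nM; the two numbers lie within the scatter of each other, so neither can be ordered against the other. Compound 3 `CCOc1ccc(NC(=O)/C=C/c2coc3cc(OC)ccc3c2=O)cc1` has not yet been measured. It differs from compound 1 in one place: 4-ethoxyphenyl in place of 2-chlorophenyl on an amide-type nitrogen. Going by the values given here, no measured pair shows the effect of such a change, and the step is expected to be small in this assay, so the expected step of a 1.0-fold lower number from compound 1 to compound 3 (0.00 log units; within the scatter) stays within the scatter. Compound 3 is therefore estimated at 1000000 nM, with a range from 500000 nM to 2000000 nM.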

Compound 3, half-maximal cytotoxic concentration: 460000 nM
Compound 3: the middle estimate sits 2.2-fold (0.34 log units) above what was measured; measured number outside the range, below it.
By their numbers in this assay, from the lowest: compound 3; then compounds 2 and 1 (each within the scatter of the next).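

The group on the amide-type nitrogen does matter in this assay, where 4-ethoxyphenyl in place of 2-chlorophenyl gives a 2.2-fold lower number from compound 1 to compound 3 (0.34 log units; beyond the scatter) as a modest change. Going by these compounds alone, this is the first step at this position, and it shows that less of compound 3 is tolerated. Nothing at hand accounts for this step.

Going by these compounds, it stays open whether losing 2-chlorophenyl or gaining 4-ethoxyphenyl drives the step. On these data alone, how a plain phenyl, a longer chain in place of the ethoxy, or an amine or carboxylic acid on that ring would read also remains unknown.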